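Ring swap at the acylhydrazide of a purine nucleoside series

A few compounds are considered here, and "the series" means these few. Any claim that something is new, unique, unknown or untested is made for them only; others in the source may bear on it.

Measured so far:
compound 1 `CCNC(=O)[C@H]1O[C@@H](n2cnc3c(NNC(=O)c4cccs4)nc(Cl)nc32)[C@H](O)[C@@H]1O` — 200 nM
compound 2 `CCNC(=O)[C@H]1O[C@@H](n2cnc3c(NNC(=O)c4sccc4C)nc(Cl)nc32)[C@H](O)[C@@H]1O` — 340 nM

In a functional assay on CHO cells for activation of adenosine receptor A2b (Homo sapiens), read by cAMP accumulation (a higher number here means that more compound is needed for the effect, a lower number that less compound is needed), compound 1 gives 200 nM and compound 2 gives 340 nM. The step of a 1.7-fold higher number from compound 1 to compound 2 (0.23 log units; within the scatter) adds a methyl on an aromatic carbon of the thiophene; compound 2 therefore sits with compound 1 within the usual scatter, and no order between the two can be read.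

Compound 3 `CCNC(=O)[C@H]1O[C@@H](n2cnc3c(NNC(=O)c4ccc[nH]4)nc(Cl)nc32)[C@H](O)[C@@H]1O` is not yet measured. The change from compound 2 is 1H-pyrrol-2-yl in place of 3-methylthiophen-2-yl on a carbonyl carbon. Among the compounds with values here, only the step of a 1.7-fold higher number from compound 1 to compound 2 (0.23 log units; within the scatter) bears on it, and it concerns the methyl alone; no measured step covers the exchange of the sulfur-containing ring for a nitrogen-containing ring with a hydrogen-bond donor. With the two measured values so close, no step beyond the scatter is expected in this assay, and the estimate for compound 3 is 250 nM (range 80 nM to 800 nM), meaning an expected step of a 1.4-fold lower number from compound 2 to compound 3 (0.13 log units; within the scatter).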

Compound 3, half-maximal effective concentration: 359 nM
Compound 3: the middle estimate sits 1.4-fold (0.16 log units) below what was measured, and the stated range covers the measured number.
By their numbers in this assay, from the lowest: compounds 1, 2 and 3 (each within the scatter of the next).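

In this assay the exchange of 3-methylthiophen-2-yl for 1H-pyrrol-2-yl on the carbonyl carbon gives a 1.1-fold higher number from compound 2 to compound 3 (0.02 log units; within the scatter) and the matching exchange from thiophen-2-yl gives a 1.8-fold higher number from compound 1 to compound 3 (0.25 log units; within the scatter) as well. The earlier pair tested only a methyl on the ring, whereas here the ring hetero atom changes from sulfur to nitrogen and a hydrogen-bond donor enters, and neither step leaves the scatter, so no order can be read among the three compounds. Nothing at hand bears on why the values stay this close.

Open, from the compounds shown here alone, is whether a six-membered ring such as phenyl or pyridin-2-yl at this carbonyl carbon would give a step beyond the scatter. Equally open, going by these compounds, is what an amine or a carboxylic acid on the ring would do.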